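A few compounds are considered here, and "the series" means these few. Any claim that something is new, unique, unknown or untested is made for them only; others in the source may bear on it.

Compound 2 `COc1cc(/C=C/C(C)=O)ccc1OCc1cn(-c2ccc(NC(=O)c3ccccc3)cc2)nn1` gives, in a functional assay on PC-3 cells (Homo sapiens) for antiproliferative activity, read by MTT assay, with a stated time of 48 h (on this read-out lower numbers stand for stronger inhibition and higher numbers for weaker inhibition), a value of 76800 nM, the highest of the two numbers seen so far; its nearest neighbour is compound 1 `COc1ccc(-n2cc(COc3ccc(/C=C/C(C)=O)cc3OC)nn2)cc1`, which in this assay gives 2010 nM. Among the compounds with values here, the only step measured between them, a 38-fold higher number from compound 1 to compound 2 (1.58 log units; beyond the scatter), came with benzamido in place of methoxy on an aromatic carbon. Compound 3 `COc1cc(/C=C/C(C)=O)ccc1OCc1cn(-c2ccccc2)nn1` differs from compound 2 by hydrogen in place of benzamido on an aromatic carbon. Within the data shown here, the one step that bears on this change is the large one from compound 1 to compound 2, which undoes the gain of the benzamido group; removing that group again is therefore expected to bring the number down, most likely towards the region of compound 1, though no measured step shows a bare hydrogen at this place. Compound 3 is expected to give about 3000 nM, within 800 nM to 12000 nM, a step of a 26-fold lower number from compound 2 to compound 3 (1.41 log units; beyond the scatter) in this assay.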

Compound 3, half-maximal inhibitory concentration: 78600 nM
For compound 3 the middle estimate is 26-fold (1.42 log units) below the measured one, and the stated range ends below it.
By their numbers in this assay, from the lowest: compound 1; then compounds 2 and 3 (each within the scatter of the next).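

In this assay the step on removing benzamido from this aromatic carbon (a 1.0-fold higher number from compound 2 to compound 3 (0.01 log units; within the scatter)) lies within the scatter, so at this place the benzamido group and hydrogen cannot be told apart. The second new step (a 39-fold higher number from compound 1 to compound 3 (1.59 log units; beyond the scatter)) is large and lies beyond the scatter, so it is the methoxy group, present only in compound 1, that sets the lower number apart from the other two compounds. No measurement at hand accounts for this difference.

Going by these compounds, whether the lower number is specific to methoxy remains open, since an ethoxy group, a hydroxyl group or an amine on the same carbon could each separate from or join it. On these data alone, it is also open whether a halogen such as fluorine or chlorine at this place would behave like methoxy or like hydrogen.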